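Swapping an Amide Tail for a Sulfonamide Tail

The source may hold more compounds than are shown below. What is called first, only, known or untested is meant among the compounds shown, and "the series" means these compounds.

Compound 1 `O=C(Nc1cccc(/C=C/C(=O)c2nc3ccccc3[nH]2)c1)c1ccc(Cl)cc1`: 7440 nM
Compound 2 `O=C(Nc1cccc(/C=C/C(=O)c2nc3ccccc3[nH]2)c1)c1cccc(Br)c1`: 4620 nM
Compound 3 `O=C(/C=C/c1cccc(NS(=O)(=O)c2cccc(Cl)c2)c1)c1nc2ccccc2[nH]1`: 2510 nM

These three compounds share a core and differ only in the group attached to the nitrogen on the aromatic ring. In a functional assay on 143B cells (Homo sapiens) for antiproliferative activity, read by MTT assay, with a stated time of 48 h (on this read-out lower numbers stand for stronger inhibition and higher numbers for weaker inhibition), compound 2 holds the second highest of the three numbers. Its nearest neighbour is compound 1, with a 1.6-fold lower number from compound 1 to compound 2 (0.21 log units; within the scatter); its furthest is compound 3, with a 1.8-fold lower number from compound 2 to compound 3 (0.26 log units; within the scatter).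

Compound 4 `Cc1cccc(S(=O)(=O)Nc2cccc(/C=C/C(=O)c3nc4ccccc4[nH]3)c2)c1` has not yet been measured. Relative to compound 2 the change is (3-methylphenyl)sulfonyl in place of (3-bromophenyl)carbonyl on a nitrogen on an aromatic ring. Within the data shown here, two measured steps bear on this. Putting a sulfonyl in place of a carbonyl gave a 1.8-fold lower number from compound 2 to compound 3 (0.26 log units; within the scatter) and, from the other starting point, a 3.0-fold lower number from compound 1 to compound 3 (0.47 log units; beyond the scatter). Among the measured compounds shown here, no measured pair shows what a 3-methylphenyl does compared with a 3-chlorophenyl or a 3-bromophenyl on a sulfonyl, so that part of the change is unknown. The expectation is therefore a small move toward a lower number, probably within the scatter: a 1.5-fold lower number from compound 2 to compound 4 (0.19 log units; within the scatter). Compound 4 is estimated at 3000 nM, with a range from 1200 nM to 7500 nM.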

Compound 4, half-maximal inhibitory concentration: 791 nM
Compound 4: the middle estimate sits 3.8-fold (0.58 log units) above what was measured, outside the stated range (below it).
By their numbers in this assay, from the lowest: compound 4; then compounds 3, 2 and 1 (each within the scatter of the next, the first and the last beyond it).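

In this assay, the group on the sulfonyl's aromatic ring turns out to matter. With the sulfonyl kept, methyl in place of chloro on an aromatic carbon gives a clear drop (a 3.2-fold lower number from compound 3 to compound 4 (0.50 log units; beyond the scatter)), so the sulfonyl alone does not set the number. Together, the sulfonyl and the methyl give the two largest steps seen in this small set (a 5.8-fold lower number from compound 2 to compound 4 (0.77 log units; beyond the scatter); a 9.4-fold lower number from compound 1 to compound 4 (0.97 log units; beyond the scatter)), and nothing measured here accounts for them.

Still open, from the compounds shown here alone, is whether the gain is special to methyl or would carry over to an ethyl, a methoxy or an amine in its place. Also open, going by these compounds, is whether a (3-methylphenyl)carbonyl on the same nitrogen would give a similar number, which would separate the part played by the sulfonyl from that of the methyl.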